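Fluoro Added to the 2-Phenylethenyl Group of Compound 3

The source may report more compounds than this note shows. Statements on the series, on what has been measured and on what is new or still open speak of the compounds shown alone.

Three compounds sharing one core were tested in a functional assay on HeLa cells (Homo sapiens) for cytotoxicity, read by MTT assay, with a stated time of 2 days, tested at 10 uM; a lower number here means a stronger effect, a higher number a weaker effect of the compound at the concentration tested. Compound 1 `CC(=O)c1cc(-c2ccccc2)cc2cc(-c3ccccc3)[nH]c12` gives 60.9%, compound 2 `CC(=O)c1cc(-c2ccc(F)cc2)cc2cc(-c3ccccc3)[nH]c12` gives 55.7%, and compound 3 `CC(=O)c1cc(/C=C/c2ccccc2)cc2cc(-c3ccccc3)[nH]c12` gives 52.5%. The steps among them, a number 5.2 percentage points lower from compound 1 to compound 2 (within the scatter), a number 8.4 percentage points lower from compound 1 to compound 3 (within the scatter) and a number 3.2 percentage points lower from compound 2 to compound 3 (within the scatter), all lie within the scatter, so compound 3 stands alongside compounds 1 and 2 rather than apart from them. Compound 4 `CC(=O)c1cc(/C=C/c2ccc(F)cc2)cc2cc(-c3ccccc3)[nH]c12` is not yet measured; it differs from compound 3 by fluoro in place of hydrogen on an aromatic carbon. Going by the values given here, the one measured step of the same kind is the step from compound 1 to compound 2, a number 5.2 percentage points lower from compound 1 to compound 2 (within the scatter), a change within the scatter. Taking that step as the guide, the change from compound 3 to compound 4 is expected to give no step beyond the scatter in this assay, with a number 3.5 percentage points lower from compound 3 to compound 4 (within the scatter) as the expected shift. Compound 4 is therefore estimated at 49%, within a range from 35% to 64%.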

Compound 4, a percentage reported as activity, at one concentration (the size of the read-out at that concentration, not a potency): 32.8%
For compound 4 the middle estimate is 16.2 percentage points above the measured one; measured number below the stated range.
By their numbers in this assay, from the lowest: compound 4; then compounds 3, 2 and 1 (each within the scatter of the next).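

In this assay, fluoro in place of hydrogen on the ring of the 2-phenylethenyl group gives a number 19.7 percentage points lower from compound 3 to compound 4 (beyond the scatter), so this position can respond to the change by more than the scatter. Only the compound that carries both fluoro and the 2-phenylethenyl group stands apart from the two phenyl-type compounds, with a number 22.9 percentage points lower from compound 2 to compound 4 (beyond the scatter) and a number 28.1 percentage points lower from compound 1 to compound 4 (beyond the scatter), while each change alone had stayed within the scatter. The effect of this one exchange therefore depends on the group that carries the ring: the same change on two cores in this assay, a number 5.2 percentage points lower (within the scatter) from compound 1 to compound 2 and a number 19.7 percentage points lower (beyond the scatter) from compound 3 to compound 4, 14.5 percentage points apart, beyond the scatter of two such steps.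

As far as these compounds go, whether chloro, methoxy or an amine at this position would follow fluoro remains open. So does whether a saturated 2-phenylethyl group in place of 2-phenylethenyl would respond to fluoro in the same way, and a read-out at one concentration gives no potency for any of these compounds.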